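Swapping an Acetyl for a Methoxybenzyl on the Nitrogen

The compounds below may be only part of what the source reports. "The series", "measured", "known", "first", "only" and "open" are said of these compounds alone.

Compound 1 `CC(=O)n1cc(/C=C(/C(=O)O)c2ccccc2)c2cc(OCc3ccccc3)ccc21` gives 57500 nM in a functional assay on A549 cells (Homo sapiens) for cytotoxicity, read by MTT assay, with a stated time of 72 h; a lower number here means a stronger inhibitor, a higher number a weaker inhibitor.
Compound 2 `CC(=O)n1cc(/C=C(/C(=O)O)c2ccc(OCc3ccccc3)cc2)c2cc(OCc3ccccc3)ccc21` gives 44100 nM in this assay.

Within the data shown here, of the two numbers measured so far, compound 1 has the highest; the nearest is compound 2, and the step of a 1.3-fold lower number from compound 1 to compound 2 (0.12 log units; within the scatter) comes from a benzyloxy group in place of hydrogen on an aromatic carbon. Compound 3 `COc1ccc(Cn2cc(/C=C(/C(=O)O)c3ccccc3)c3cc(OCc4ccccc4)ccc32)cc1` has not yet been measured. It differs from compound 1 in one place: 4-methoxybenzyl in place of acetyl on an aromatic nitrogen. Among the measured compounds shown here, no measured step touches the group on the aromatic nitrogen; the only step available, from compound 1 to compound 2, changed a different part of the molecule and stayed within the scatter. The data thus give no reason to expect a large move in either direction in this assay, and the expected step is modest, a 1.4-fold lower number from compound 1 to compound 3 (0.16 log units; within the scatter). Compound 3 is expected to give about 40000 nM, with a likely range from 12000 nM to 130000 nM.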

Compound 3, half-maximal inhibitory concentration: 1000 nM
For compound 3 the middle estimate is 40-fold (1.60 log units) above the measured one; measured number below the stated range.
By their numbers in this assay, from the lowest: compound 3; then compounds 2 and 1 (each within the scatter of the next).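

The group on the aromatic nitrogen matters far more in this assay than the earlier compounds could reveal: 4-methoxybenzyl in place of acetyl gives a 58-fold lower number from compound 1 to compound 3 (1.76 log units; beyond the scatter) and is the first change shown to go beyond the scatter. The only earlier step, a 1.3-fold lower number from compound 1 to compound 2 (0.12 log units; within the scatter), changed a different part of the molecule, so this nitrogen is the one place shown where a single swap moves the number strongly. Nothing measured here explains why this swap has such a large effect.

Going by these compounds, it remains open whether the whole 4-methoxybenzyl group is needed, since a plain benzyl or a small methyl on the same nitrogen would separate the contribution of the ring from that of its methoxy group. Also open, on these data alone, is whether an amine on that ring would keep the number low, and whether the benzyloxy group of compound 2 would add anything once the nitrogen carries 4-methoxybenzyl.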